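A Chloro Added to the Phenyl Ring of Compound 3

The source may report more compounds than this note shows. Statements on the series, on what has been measured and on what is new or still open speak of the compounds shown alone.

Measured in a functional assay on Daoy cells (Homo sapiens) for antiproliferative activity, read by trypan blue exclusion and crystal violet staining, with a stated time of 72 h; a higher number here means a weaker inhibitor, a lower number a stronger inhibitor:
compound 1, `CCCC(=O)NC(c1ccc(C)cc1)c1cc(Cl)c2cccnc2c1O`: 100 nM
compound 2, `CCCC(=O)NC(c1ccc(Cl)cc1)c1cc(Cl)c2cccnc2c1O`: 100 nM
compound 3, `CCCC(=O)NC(c1ccccc1)c1cc(Cl)c2cccnc2c1O`: 110 nM

Compound 3 gives the highest of the three numbers, yet its steps to compound 1 and to compound 2 both lie within the scatter, so the three stand together. Compound 4, `CCCC(=O)NC(c1ccccc1Cl)c1cc(Cl)c2cccnc2c1O`, differs from compound 3 by chloro in place of hydrogen on an aromatic carbon. The measured steps that bear on it all alter a group on the same phenyl ring: no change at the digits printed from compound 1 to compound 2 (within the scatter), a 1.1-fold higher number from compound 1 to compound 3 (0.04 log units; within the scatter) and a 1.1-fold higher number from compound 2 to compound 3 (0.04 log units; within the scatter), none of them beyond the scatter. Within the data shown here, no measured step places a group ortho to a large group, so the expectation rests on the indifference of this assay to the phenyl substituents seen so far. Compound 4 is therefore expected to show a 1.1-fold higher number from compound 3 to compound 4 (0.04 log units; within the scatter). Compound 4 is estimated at 120 nM, with a range from 50 nM to 300 nM.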

Compound 4, half-maximal inhibitory concentration: 100 nM
Compound 4: the middle estimate sits 1.2-fold (0.08 log units) above what was measured; low and high end bracket the measured number.
By their numbers in this assay, from the lowest: compounds 1, 2, 4 and 3 (each within the scatter of the next).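

In this assay, among these compounds, chloro ortho to a large group, a place the earlier compounds left empty, gives a 1.1-fold lower number from compound 3 to compound 4 (0.04 log units; within the scatter) and so moves nothing beyond the scatter. Likewise 2-chlorophenyl in place of 4-chlorophenyl gives no change at the digits printed from compound 2 to compound 4 (within the scatter) and 2-chlorophenyl in place of 4-methylphenyl gives no change at the digits printed from compound 1 to compound 4 (within the scatter) so across these four compounds neither the phenyl substituent nor its place separates the numbers. No evidence bearing on this result is at hand.

Still open, as far as these compounds go, is whether a methoxy or dimethylamino group on the phenyl ring would stay within the scatter. Also open, from the compounds shown here alone, is whether a longer chain on the amide carbonyl, or an amine in place of the chloro on the core, would do so.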